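Nitro on the Lactam Benzyl Ring of Compound 1

A few compounds are considered here, and "the series" means these few. Any claim that something is new, unique, unknown or untested is made for them only; others in the source may bear on it.

Compound 1 `N=C(NCc1ccccc1)[C@@H]1CCC(=O)N1Cc1ccccc1` gives 20.7% in a functional assay on SH-SY5Y cells (Homo sapiens) for cytotoxicity, read by MTT assay, with stated times of 8 h, 30 min and 12 h, tested at 5 uM (a higher number here means a stronger effect of the compound at the concentration tested, a lower number a weaker effect), and stands lowest of the two numbers shown. Within the data shown here, compound 2 `N=C(NCc1ccc(O)cc1)[C@@H]1CCC(=O)N1Cc1ccccc1` gives 37.6% in this assay, and the only measured step, a number 16.9 percentage points higher from compound 1 to compound 2 (beyond the scatter), is a modest rise. Compound 3 `N=C(NCc1ccccc1)[C@@H]1CCC(=O)N1Cc1ccc([N+](=O)[O-])cc1` differs from compound 1 by nitro in place of hydrogen on an aromatic carbon, on the other six-membered ring than the hydroxy of compound 2, so that step bears only loosely on it. A small rise or no change beyond the scatter is therefore expected, an estimated a number 7.3 percentage points higher from compound 1 to compound 3 (within the scatter), so compound 3 is expected to give 28%, within 14% to 44%.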

Compound 3, a percentage reported as activity, at one concentration (the size of the read-out at that concentration, not a potency): 25.6%
For compound 3 the middle estimate is 2.4 percentage points above the measured one; the range from low to high includes it.
By their numbers in this assay, from the lowest: compounds 1 and 3 (each within the scatter of the next); then compound 2.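

Nitro on this ring, para to a large group, gives a number 4.9 percentage points higher from compound 1 to compound 3 (within the scatter) in this assay, so compound 3 cannot be told apart from compound 1 in this read-out. At this position, then, a group of 3 heavy atoms replaces hydrogen without a change beyond the scatter, unlike the hydroxy step on the other ring. Nothing available explains this result.

Going by these compounds, it remains open whether an amine or a carboxylic acid at this position would also stay within the scatter. On these data alone, it is equally open whether hydroxy here would reproduce a number 16.9 percentage points higher from compound 1 to compound 2 (beyond the scatter), seen on the other ring.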